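Bromo in Place of Nitro on the Aromatic Ring

This account rests on a few compounds, and the source may have more. Where it says the series, first, only, none or still open, it means among the compounds named here.

Within the data shown here, in a functional assay on RAW264.7 cells (Mus musculus) for inhibition, read by Griess assay, with stated times of 3 h and 24 h (on this read-out lower numbers stand for stronger inhibition and higher numbers for weaker inhibition), compound 1 `C=C1CCC2[C@](C)(CO)[C@H](O)CC[C@@]2(C)[C@@H]1CCOc1ccc(C(C)(C)C)cc1` gives 35800 nM and compound 2 `C=C1CCC2[C@](C)(CO)[C@H](O)CC[C@@]2(C)[C@@H]1CCOc1ccc([N+](=O)[O-])cc1` gives 3380 nM as the lower of the only two numbers so far. Compound 3 `C=C1CCC2[C@](C)(CO)[C@H](O)CC[C@@]2(C)[C@@H]1CCOc1ccc(Br)cc1` keeps the shared core but has bromo in place of nitro on an aromatic carbon and still awaits measurement. Among the measured compounds shown here, only one measured step bears on this change: an 11-fold lower number from compound 1 to compound 2 (1.02 log units; beyond the scatter) came with nitro in place of tert-butyl on an aromatic carbon, and it is a large step beyond the scatter. For the measured compounds named here, no compound with bromo has a measured value, so the size of the next step is uncertain. The expected change is a 2.7-fold higher number from compound 2 to compound 3 (0.43 log units; beyond the scatter) in this assay as a moderate move toward weaker inhibition, smaller than that earlier step. The estimate for compound 3 is 9000 nM with an expected range from 3000 nM to 27000 nM for a new measurement.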

Compound 3, half-maximal inhibitory concentration: 40300 nM
Estimate against measurement, compound 3: 4.5-fold (0.65 log units) below, and the stated range ends below it.
By their numbers in this assay, from the lowest: compound 2; then compounds 1 and 3 (each within the scatter of the next).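

In this assay there is a 12-fold higher number from compound 2 to compound 3 (1.08 log units; beyond the scatter) when bromo replaces nitro, so the stronger inhibition seen with nitro does not carry over to bromo at this position. Bromo and tert-butyl cannot be told apart here, with a 1.1-fold higher number from compound 1 to compound 3 (0.05 log units; within the scatter) that stays within the scatter, which leaves nitro as the only one of these three groups that stands apart. Nothing measured here explains why nitro differs from the other two.

Three groups are too few to show what the stronger inhibition with nitro depends on. A nitrile, a trifluoromethyl group, an amine or a carboxylic acid on the same aromatic carbon could show whether nitro is a lone case or one of a wider set of groups that behave alike.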